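Chain length and the weakening of activity in a pyridinol series

This account rests on a few compounds, and the source may have more. Where it says the series, first, only, none or still open, it means among the compounds named here.

Measured so far:
Compound 1, `CCCCCCCCCCCCCCCCc1c(C)c(N(C)C)nc(C)c1O`: 80%
Compound 2, `CCCCCCCCCCc1c(C)c(N(C)C)nc(C)c1O`: 40%

In a functional assay on cells (Lymphocyte), read by a luciferase reporter and ATP content, with a stated time of 48 h, tested at 10 uM (a higher number here means a weaker effect of the compound at the concentration tested, a lower number a stronger effect), compound 2 gives 40%, the lowest of the two numbers measured, meaning the stronger effect of the pair. Within the data shown here, the only neighbour is compound 1, which sits a good deal higher; the step of a number 40 percentage points lower from compound 1 to compound 2 (beyond the scatter) goes with hydrogen in place of hexyl on a saturated chain carbon, ten or more bonds along the chain from an aromatic carbon. In other words, shortening the chain made the effect stronger.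

The next compound, compound 3, `CCCCCCCCCCCCCCCCCCCc1c(C)c(N(C)C)nc(C)c1O`, moves in the opposite direction: nonyl in place of hydrogen on a saturated chain carbon, ten or more bonds along the chain from an aromatic carbon. The chain becomes longer than in compound 2 and even longer than in compound 1. Among the measured compounds shown here, the one step on hand suggests that lengthening the chain raises the number in this assay, so a large rise is expected here, with compound 3 back at or above the weak effect of compound 1. The expected step is a number 45 percentage points higher from compound 2 to compound 3 (beyond the scatter). The estimate for compound 3 is 85%, within a range from 65% to 100%.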

Compound 3, a percentage reported as activity, at one concentration (the size of the read-out at that concentration, not a potency): 103%
Compound 3: middle estimate off by 18 percentage points, on the low side, outside the stated range (above it).
By their numbers in this assay, from the lowest: compound 2; then compound 1; then compound 3.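

In this assay, the effect of chain length now shows across three compounds rather than one pair: the number rises each time the chain grows, with no compound shown going against that order. The large step of a number 63 percentage points higher from compound 2 to compound 3 (beyond the scatter) comes with nonyl in place of hydrogen, and compound 3 is the weakest of the three. Even the smaller change, propyl in place of hydrogen, gives a number 23 percentage points higher from compound 1 to compound 3 (beyond the scatter), so the weakening has not levelled off at the chain of compound 1, and nothing available explains why chain length acts in this way.

The compounds shown leave open whether the trend continues below the chain of compound 2, to a hexyl or butyl group, or whether the effect peaks somewhere along the way and then fades as the chain gets shorter. They also leave open whether only the length of the chain matters, or whether a chain ending in an amine or a carboxylic acid would follow the same order in this assay.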